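Trifluoromethyl in place of tert-butyl on compound 3

The source may hold more compounds than are shown below. What is called first, only, known or untested is meant among the compounds shown, and "the series" means these compounds.

Compound 1 `O=C(/C=C/c1cccnc1)NCCCCCCc1cccc(S(=O)(=O)Nc2ccccc2)c1`: 30.4 nM
Compound 2 `Cc1ccc(C)c(NS(=O)(=O)c2cccc(CCCCCCNC(=O)/C=C/c3cccnc3)c2)c1`: 22.6 nM
Compound 3 `CC(C)(C)c1ccc(NS(=O)(=O)c2cccc(CCCCCCNC(=O)/C=C/c3cccnc3)c2)cc1`: 1520 nM

In a functional assay on HeLa cells (Homo sapiens) for inhibition, read by CCK-8 assay, with a stated time of 72 h (a lower number here means a stronger inhibitor, a higher number a weaker inhibitor), compound 3 stands highest of the three at 1520 nM, with its steps to both others beyond the scatter. Compound 4 `O=C(/C=C/c1cccnc1)NCCCCCCc1cccc(S(=O)(=O)Nc2ccc(C(F)(F)F)cc2)c1` carries trifluoromethyl in place of tert-butyl on an aromatic carbon, para to a large group: trifluoromethyl in place of tert-butyl on an aromatic carbon.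

Among the measured compounds shown here, two measured steps bear directly on this change, and both are large. Adding tert-butyl gives a 50-fold higher number from compound 1 to compound 3 (1.70 log units; beyond the scatter), and the exchange on the sulfonamide nitrogen gives a 67-fold higher number from compound 2 to compound 3 (1.83 log units; beyond the scatter). By contrast, a 1.3-fold lower number from compound 1 to compound 2 (0.13 log units; within the scatter) stays within the scatter. For the measured compounds named here, no measured compound carries trifluoromethyl, so how much of the rise it reverses remains open. Part of that rise, though not all, is expected to be recovered. The expected step in this assay is toward a lower number, a 13-fold lower number from compound 3 to compound 4 (1.10 log units; beyond the scatter). For compound 4 the estimated value is 120 nM, with an expected range of 30 nM to 600 nM.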

Compound 4, half-maximal inhibitory concentration: 1450 nM
Compound 4: middle estimate off by 12-fold (1.08 log units), on the low side; measured number above the stated range.
By their numbers in this assay, from the lowest: compounds 2 and 1 (each within the scatter of the next); then compounds 4 and 3 (each within the scatter of the next).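

In this assay, trifluoromethyl in place of tert-butyl gives a 1.0-fold lower number from compound 3 to compound 4 (0.02 log units; within the scatter) and so separates compound 3 from compound 4 by no more than the scatter, which shows that the high number at this aromatic carbon is not confined to tert-butyl. Trifluoromethyl in place of hydrogen gives a 48-fold higher number from compound 1 to compound 4 (1.68 log units; beyond the scatter) and the exchange on the sulfonamide nitrogen gives a 64-fold higher number from compound 2 to compound 4 (1.81 log units; beyond the scatter) as steps about as large as those seen for compound 3, so two different groups of equal heavy-atom count at this place stand well apart from compound 1 and compound 2. No measured data bear on the reason for this result.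

Still open, as far as these compounds go, is whether a smaller group here, such as a single fluorine, keeps the number of compound 1 or raises it like these two groups. An amine or a carboxylic acid at the same place would show whether the rise holds beyond these two groups.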